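Morpholine Sulfonyl in Place of a Sulfoximine on the Core

This account rests on a few compounds, and the source may have more. Where it says the series, first, only, none or still open, it means among the compounds named here.

Measured compounds:
- compound 1, `CCOC(=O)[C@@H]1CCCN(S(=O)(=O)c2ccc(S(=N)(=O)N(CC)CC)cc2)C1`: 2600 nM
- compound 2, `CC(C)c1noc(C2CCN(C(=O)[C@@H]3CCCN(S(=O)(=O)c4ccc(S(=O)(=O)C(C)C)cc4)C3)CC2)n1`: 50 nM
- compound 3, `CCOC(=O)C1CCN(S(=O)(=O)c2ccc(S(=O)(=O)N(CC)CC)cc2)CC1`: 27200 nM

Of the compounds shown here, three have been measured in a functional assay on MIA PaCa-2 cells (Homo sapiens) for inhibition, read by MTT assay, with a stated time of 7 days; on this read-out lower numbers stand for stronger inhibition and higher numbers for weaker inhibition. Compound 1 stands second highest of the three numbers; compound 3 is its nearest neighbour, with a higher number, beyond the scatter, while compound 2 lies furthest away, with a lower number, also beyond the scatter. Among the compounds with values here, no single-change step between measured compounds is available, so the ester-bearing core of compound 1 is the only close anchor for what follows.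

Compound 4, `CCOC(=O)[C@@H]1CCCN(S(=O)(=O)c2ccc(S(=O)(=O)N3CCOCC3)cc2)C1`, keeps the ethyl ester and the sulfonyl-linked core of compound 1 and differs only by a group of 9 heavy atoms (4 carbon, 1 nitrogen, 3 oxygen, 1 sulfur; one six-membered non-aromatic ring with 2 hetero atoms) in place of a group of 8 heavy atoms (4 carbon, 2 nitrogen, 1 oxygen, 1 sulfur; no ring), on an aromatic carbon. The replacement keeps the sulfonyl attachment but trades an open chain for a ring and removes the single hydrogen-bond donor.

Without a measured step of this kind, the change from compound 1 to compound 4 is expected to stay small in this assay, at most a modest move toward a weaker number, that is, a step of a 1.5-fold higher number from compound 1 to compound 4 (0.19 log units; within the scatter) is expected. Compound 4 is therefore estimated at 4000 nM, within a range of 1000 nM to 15000 nM.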

Compound 4, half-maximal inhibitory concentration: 23500 nM
For compound 4 the middle estimate is 5.9-fold (0.77 log units) below the measured one; measured number outside the range, above it.
By their numbers in this assay, from the lowest: compound 2; then compound 1; then compounds 4 and 3 (each within the scatter of the next).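

Placing (morpholin-4-yl)sulfonyl on the aromatic carbon, para to a large group, in place of the open-chain group of 8 heavy atoms gives in this assay a 9.0-fold higher number from compound 1 to compound 4 (0.96 log units; beyond the scatter) and supplies the first single-place comparison among the compounds shown. It shows that, with the ethyl ester and the rest of the shared core held constant, this position is not indifferent to the change, although the swap alters the ring count and the numbers of hydrogen-bond donors and acceptors together, so the step cannot be assigned to any one of these differences. No measurement offered here accounts for the size of the step.

The compounds shown leave open whether a piperidin-1-ylsulfonyl group, which would keep a six-membered ring without the ring oxygen, or an open-chain diethylaminosulfonyl group on this same core would give a number close to that of compound 1 or to that of compound 4. They also leave open whether the same replacement would give a step of similar size if a carboxylic acid stood in place of the ethyl ester.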